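Phenoxy in Place of Methyl(phenyl)amino on a Sulfonyl Sulfur

The compounds below may be only part of what the source reports. "The series", "measured", "known", "first", "only" and "open" are said of these compounds alone.

Measured compounds:
Compound 1, `CC1(C)C=C(n2ccccc2=O)c2cc(S(=O)(=O)Nc3ccccc3)ccc2O1`: 7.85%; 88% (2 entries)
Compound 2, `CN(c1ccccc1)S(=O)(=O)c1ccc2c(c1)C(n1ccccc1=O)=CC(C)(C)O2`: 86.5%

In a functional assay on the whole organism (trachea) with Rattus norvegicus as the target (a lower number here means a smaller maximal response, a higher number a larger maximal response), compound 1 gives 7.85%; 88% (2 entries), and the wide spread of its repeated entries, (the several entries of compound 1 in this assay, 7.85%; 88% (2 entries)), shows how far two measurements of one compound can lie apart here. In this assay, going by the values given here, compound 2 gives 86.5%, the only number reported for it, while one further entry for compound 2 carries no single number. Among the compounds with values here, no two measured compounds differ in one place, so no measured step exists. Compound 3, `CC1(C)C=C(n2ccccc2=O)c2cc(S(=O)(=O)Oc3ccccc3)ccc2O1`, is not yet measured. It differs from compound 2 by phenoxy in place of methyl(phenyl)amino on a sulfonyl sulfur. Within the data shown here, with only one number for compound 2 and no measured step to lean on, the expected change in this assay from compound 2 to compound 3 is none beyond the usual scatter, in either direction. The estimate for compound 3 is therefore 80%, ranging from 40% to 95%, which would be a step of a number 6.5 percentage points lower from compound 2 to compound 3 (within the scatter) from compound 2 to compound 3 and is wide because the entries of compound 1, (the several entries of compound 1 in this assay, 7.85%; 88% (2 entries)), scatter so much.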

Compound 3, largest response reached (Emax), in percent of the reference or control that the assay uses: 86.7%
Beside the measured number, compound 3's estimate is 6.7 percentage points below it; measured number inside the range.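

In this assay, going by these compounds alone, putting phenoxy in place of methyl(phenyl)amino on a sulfonyl sulfur gives a number 0.2 percentage points higher from compound 2 to compound 3 (within the scatter) and so provides the first measured step at this position. The sulfonyl sulfur thus carries either group, one counted with no hydrogen-bond acceptor and the other with one, and the maximal response shows no shift that stands out from the scatter. This finding rests on a single pair of compounds, and any reading of it must allow for how far repeated measurements can lie apart in this assay: (the several entries of compound 1 in this assay, 7.85%; 88% (2 entries)).

The compounds shown leave open whether a morpholine, a benzyloxy group or a simple methoxy group on the same sulfonyl sulfur would also keep the maximal response in this range, since one step says nothing about groups of another kind. They also leave open how compound 2 and compound 3 stand against compound 1, whose entries of 7.85%; 88% (2 entries) in this assay lie too far apart to fix a single value for it.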